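From a 3-methylbenzyl to an acetyl group on nitrogen

This account rests on a few compounds, and the source may have more. Where it says the series, first, only, none or still open, it means among the compounds named here.

Compound 1 `CC(=O)Oc1ccc2c(c1)C(C)=CC(C)(C)N2Cc1ccccc1` gives 24000 nM
Compound 2 `CC(=O)Oc1ccc2c(c1)C(C)=CC(C)(C)N2Cc1ccc(Cl)cc1` gives 22000 nM
Compound 3 `CC(=O)Oc1ccc2c(c1)C(C)=CC(C)(C)N2Cc1cccc(C)c1` gives 28000 nM

All three values come from an ADME assay on L6 cells (Rattus norvegicus) for cytotoxicity, read by resazurin assay, with a stated time of 70 h (a higher number here means a weaker inhibitor, a lower number a stronger inhibitor), and they sit close together: compound 3 lies within the scatter of both compound 1 and compound 2. Compound 4 `CC(=O)Oc1ccc2c(c1)C(C)=CC(C)(C)N2C(C)=O` has not yet been measured. It keeps the shared core but carries acetyl in place of 3-methylbenzyl on the nitrogen (acetyl in place of 3-methylbenzyl on a nitrogen on an aromatic ring in a ring). The measured steps bear on this change only indirectly. Adding chloro (a 1.1-fold lower number from compound 1 to compound 2 (0.04 log units; within the scatter)) or methyl (a 1.2-fold higher number from compound 1 to compound 3 (0.07 log units; within the scatter)) to the aromatic ring, or exchanging one substituted benzyl group for the other (a 1.3-fold higher number from compound 2 to compound 3 (0.10 log units; within the scatter)), stayed within the scatter. None of these steps removes the whole aromatic ring, so they set no size for this much larger change. Going by the values given here, a step beyond the scatter toward a higher number seems likelier than not, though no measured compound shows one. The estimated step is a 2.1-fold higher number from compound 3 to compound 4 (0.33 log units; beyond the scatter) and remains uncertain. Compound 4 is expected at 60000 nM in this assay (estimated range 20000 nM to 180000 nM).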

Compound 4, half-maximal inhibitory concentration: 160000 nM
Compound 4: the middle estimate sits 2.7-fold (0.43 log units) below what was measured, and the stated range covers the measured number.
By their numbers in this assay, from the lowest: compounds 2, 1 and 3 (each within the scatter of the next); then compound 4.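

Replacing the group on the nitrogen with acetyl gives a 5.7-fold higher number from compound 3 to compound 4 (0.76 log units; beyond the scatter) and, from the other two compounds, a 6.7-fold higher number from compound 1 to compound 4 (0.82 log units; beyond the scatter) and a 7.3-fold higher number from compound 2 to compound 4 (0.86 log units; beyond the scatter) in this assay and so leaves compound 4 the weakest of the four. Going by these compounds alone, the earlier changes, made on the aromatic ring of the benzyl group, all stayed within the scatter, whereas this exchange of the whole group on the nitrogen is the first to move the number beyond it. No measurement at hand gives a reason for this shift.

The compounds shown cannot separate the loss of the aromatic ring from the arrival of the carbonyl, a question that a benzoyl group or a plain ethyl group on the nitrogen would address. Also open, on these data alone, is how a longer chain or an amine at this nitrogen would behave.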